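A few compounds are considered here, and "the series" means these few. Any claim that something is new, unique, unknown or untested is made for them only; others in the source may bear on it.

Working notes on the series in an assay on cells for inhibition of HSP60/HSP10 (Homo sapiens), with a stated time of 60 min; on this read-out lower numbers stand for stronger inhibition and higher numbers for weaker inhibition. Compound 1 `N#Cc1ccc(S(=O)(=O)Nc2ccc(-c3nc4cc(NS(=O)(=O)c5ccc(C#N)cc5)ccc4o3)cc2)cc1` carries two aryl sulfonamide arms on the shared core; in this assay compound 1 gives 49000 nM. Compound 2 `O=S(=O)(Nc1ccc2oc(-c3ccccc3)nc2c1)c1ccc(Cl)c(Cl)c1` reaches only a limit in this assay, reported as > 100000 nM, which is a boundary of the assay and not a number (the limit of > 100000 nM in this assay, at which 1 of the 3 values shown sits). Compound 3 `O=S(=O)(Nc1ccc(-c2nc3ccccc3o2)cc1)c1ccc(Cl)s1` gives 31000 nM in this assay. Of the two numbers, compound 3 carries the lower one, and its nearest neighbour is compound 1, whose number sits within the scatter of that of compound 3, so no order between the two can be read. Among the measured compounds shown here, no step between measured compounds that differ in one place is available in this set.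

Compound 4 `CS(=O)(=O)Nc1ccc(-c2nc3ccccc3o2)cc1` has not been measured. From compound 3 it differs in one place: methyl in place of 5-chlorothiophen-2-yl on a sulfonyl sulfur. The measured compounds contain no change of this kind, so the expectation rests on the change itself and on the weak numbers already seen. A loss in this assay is expected, with a fair chance that only a limit is returned; the expected step is a 2.3-fold higher number from compound 3 to compound 4 (0.35 log units; beyond the scatter). For compound 4 the estimate is 70000 nM, with a range from 25000 nM to 200000 nM.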

Compound 4, half-maximal inhibitory concentration: > 100000 nM
Compound 4 gave a limit, no number (the forecaster's own chance of this, stated with the estimate: 40%); middle value at least 1.4-fold (0.15 log units) away from the limit.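

Among the compounds shown here, this pair gives the first step at a single place. On a sulfonyl sulfur whose other neighbours are the sulfonamide nitrogen, methyl in place of 5-chlorothiophen-2-yl gives an at least 3.2-fold higher number from compound 3 to compound 4 (0.50 log units; beyond the scatter) in this assay, so within this pair a measurable number is kept only with the 5-chlorothiophen-2-yl group on that sulfur. The result for compound 4 is a limit of the assay, and compound 4 now stands at the same boundary as compound 2: the limit of > 100000 nM in this assay, at which 2 of the 4 values shown sit.

The whole 5-chlorothiophen-2-yl group leaves in one change, so the pair cannot separate the part played by the five-membered aromatic ring from that of its chlorine; a thiophen-2-yl group without chlorine on the same sulfur would divide the two. Also open, going by these compounds, is whether a phenyl ring, or a longer chain ending in an amine or a carboxylic acid, on that sulfur would stay near compound 3 (31000 nM) or give a clearly lower number in this assay.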